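This account rests on a few compounds, and the source may have more. Where it says the series, first, only, none or still open, it means among the compounds named here.

Measured so far in this series:

compound 1, `CCCCCCC[C@H]1C[C@H](Br)CCN1S(=O)(=O)c1ccc(C)cc1`; in a functional assay on SW1573 cells (Homo sapiens) for antiproliferative activity, read by sulforhodamine B assay, with a stated time of 48 h (on this read-out lower numbers stand for stronger inhibition of growth and higher numbers for weaker inhibition of growth), compound 1 gives > 100000 nM, which is a limit of the assay and not a number.
compound 2, `Cc1ccc(S(=O)(=O)N2CC=C(Cl)CC2)cc1`; in this assay compound 2 gives > 100000 nM, again a limit of the assay.
compound 3, `Cc1ccc(S(=O)(=O)N2CC=C(Br)CC2)cc1`; in this assay compound 3 gives > 100000 nM, also a limit of the assay.

Compound 3 therefore stands where every measured value of the series stands so far, at the limit of > 100000 nM in this assay, at which 3 of the 3 values shown sit. For the measured compounds named here, the only one-place step among the measured compounds, a step that the two limits leave unreadable from compound 2 to compound 3, runs between two limits and so gives no readable size in either direction.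

Compound 4, `CCCCCCCC1C=C(Br)CCN1S(=O)(=O)c1ccc(C)cc1`, differs from compound 3 by heptyl in place of hydrogen on a saturated ring carbon. Going by the values given here, no measured step bears directly on this change, since the heptyl group is nowhere added in a single step between two numbered values. What can be said is that compound 1, which also carries a heptyl group on the shared core, sits at the same limit as compound 3 and compound 2. Among the compounds with values here, nothing among the measured compounds points to a reading below the limit, so for compound 4 in this assay no step beyond the scatter is expected, the estimated step being a step that the limit leaves unreadable from compound 3 to compound 4. The expected value for compound 4 is 150000 nM, with a range from 40000 nM to 600000 nM, and most likely the assay again reports only a limit.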

Compound 4, concentration for 50% growth inhibition: 49000 nM
For compound 4 the middle estimate is 3.1-fold (0.49 log units) above the measured one; the range from low to high includes it.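

Heptyl in place of hydrogen on a saturated ring carbon, next to the ring nitrogen, gives an at least 2.0-fold lower number from compound 3 to compound 4 (0.30 log units; that floor lies within the scatter) in this assay. Compound 4 is the only compound shown with a number, and the rest of the series gives none: the limit of > 100000 nM in this assay, at which 3 of the 4 values shown sit. Compound 1, which also carries a heptyl group, gives > 100000 nM, which is a limit of the assay, so the heptyl group does not bring a readable value in every compound that has it.

The compounds shown leave open whether the number follows chain length on this saturated ring carbon, which a butyl or a dodecyl group in place of heptyl would test. Also open, on these data alone, are whether an amine or a carboxylic acid at the end of the chain would move the value, and whether the bromo group matters once heptyl is present, which the chloro counterpart of compound 4 would show.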